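Working notes: fluoro in place of methoxy

The compounds below may be only part of what the source reports. "The series", "measured", "known", "first", "only" and "open" are said of these compounds alone.

Compound 1 `Cn1ncc2c(-c3ccc(F)cc3)cc(NNC(=O)Nc3cc(Cl)cc(Cl)c3)nc21`: 39100 nM
Compound 2 `COc1ccc(-c2cc(NNC(=O)Nc3cc(Cl)nc(OC)c3)nc3c2cnn3C)cc1`: 54200 nM

In a functional assay on HCT-116 cells (Homo sapiens) for cytotoxicity, read by MTT assay, with a stated time of 48 h, in the presence of a further agent that is not named here (a higher number here means that more compound is needed for the effect, a lower number that less compound is needed), compound 2 gives 54200 nM, which lies within the usual scatter of compound 1 at 39100 nM. Compound 3 `COc1cc(NC(=O)NNc2cc(-c3ccc(F)cc3)c3cnn(C)c3n2)cc(Cl)n1` has not yet been measured. It departs from compound 2 in one place: fluoro in place of methoxy on an aromatic carbon. This is fluoro in place of methoxy on an aromatic carbon, or 4-methoxyphenyl to 4-fluorophenyl when cut one bond further out. Within the data shown here, no measured pair shows this change alone, so the data give no direct size or direction for it. Among the measured compounds shown here, the only guide is the narrow spread of the two values so far, and no shift beyond the scatter is expected in this assay. The expected 1.2-fold lower number from compound 2 to compound 3 (0.08 log units; within the scatter) stays within the scatter. For compound 3 the estimated value is 45000 nM, with an expected range of 20000 nM to 100000 nM.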

Compound 3, half-maximal effective concentration: 75300 nM
Beside the measured number, compound 3's estimate is 1.7-fold (0.22 log units) below it, and the stated range covers the measured number.
By their numbers in this assay, from the lowest: compounds 1, 2 and 3 (each within the scatter of the next).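

Among these compounds, for this position, on an aromatic carbon of a six-membered aromatic ring of carbon only, the exchange of 4-methoxyphenyl for 4-fluorophenyl now has a measured size in this assay, with a 1.4-fold higher number from compound 2 to compound 3 (0.14 log units; within the scatter), so the first direct reading of this change lies within the scatter. The series also gains a reading for 2-chloro-6-methoxypyridin-4-yl in place of 3,5-dichlorophenyl on an amide-type nitrogen, with a 1.9-fold higher number from compound 1 to compound 3 (0.28 log units; within the scatter), again within the scatter. No measurement on hand offers an explanation for either step.

As far as these compounds go, whether an amine or a carboxylic acid in place of the fluoro would give a step beyond the scatter remains open. Also open, from the compounds shown here alone, is whether either step would hold without the further agent present in this assay.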